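The source may report more compounds than this note shows. Statements on the series, on what has been measured and on what is new or still open speak of the compounds shown alone.

Measured compounds:
compound 1 `COc1cccc(CNCc2c(C(=O)O)n(Cc3ccc(O)cc3)c3cc(C(C)C)ccc23)c1`, 5340 nM
compound 2 `COc1cccc(CNCc2c(C(=O)O)n(Cc3ccccc3)c3cc(C)ccc23)c1`, 7310 nM

In a functional assay on Hep 3B2 cells (Homo sapiens) for antiproliferative activity, read by MTT assay, with a stated time of 72 h (on this read-out lower numbers stand for stronger inhibition and higher numbers for weaker inhibition), compound 1 gives 5340 nM, and in this assay compound 2 gives 7310 nM. Within the data shown here, the two numbers lie within the usual scatter of each other, so neither compound stands apart on this read-out, and no step between the measured pair can be read from them.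

Compound 3 `COc1cccc(CNCc2c(C(=O)O)n(Cc3ccccc3F)c3cc(C(C)C)ccc23)c1` is not yet measured in this assay. It differs from compound 1 in one place: 2-fluorophenyl in place of 4-hydroxyphenyl on a saturated chain carbon bound to an aromatic nitrogen. The change removes the only hydroxyl of that ring and brings in a fluorine, while the rest of the shared core of compound 1 is kept unchanged.

Nothing among the two measured compounds shows how such a change affects this assay, so compound 3 is expected to stay close to compound 1, with a step from compound 1 to compound 3 of a 1.2-fold higher number from compound 1 to compound 3 (0.09 log units; within the scatter) that is expected to remain within the scatter. Compound 3 is therefore estimated at 6500 nM, with a range from 2500 nM to 16000 nM.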

Compound 3, half-maximal inhibitory concentration: 5190 nM
Beside the measured number, compound 3's estimate is 1.3-fold (0.10 log units) above it; low and high end bracket the measured number.
By their numbers in this assay, from the lowest: compounds 3, 1 and 2 (each within the scatter of the next).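

In this assay, among these compounds, 2-fluorophenyl in place of 4-hydroxyphenyl on a saturated chain carbon bound to an aromatic nitrogen gives a 1.0-fold lower number from compound 1 to compound 3 (0.01 log units; within the scatter), the first step that can be read at this position. The number stays within the scatter although the group that enters has no hydrogen-bond donor or acceptor, while the group that leaves has one of each, so this read-out does not depend on that hydroxyl in compound 1. Nothing available accounts for this result.

Going by these compounds, the step joins the loss of the hydroxyl and the arrival of the fluorine in one change, so the share of each stays open. On these data alone, it also remains open whether an amine or a carboxylic acid on that ring, or a longer chain at this place, would leave the number unchanged.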